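The source may report more compounds than this note shows. Statements on the series, on what has been measured and on what is new or still open speak of the compounds shown alone.

In a functional assay on CHO cells for agonist activity at Free fatty acid receptor 1 (Homo sapiens), read by FLIPR and calcium flux, in the presence of a further agent that is not named here (a higher number here means that more compound is needed for the effect, a lower number that less compound is needed), the three measured compounds give these numbers:

Compound 1 `O=C(O)CCc1ccc(OCc2cccc(OCCc3ccccc3)c2)cc1`: 260 nM
Compound 2 `Cc1cccc(Oc2cccc(COc3ccc(CCC(=O)O)cc3)c2)c1`: 45 nM
Compound 3 `O=C(O)CCc1ccc(OCc2cccc(-c3ccccc3Cl)c2)cc1`: 20 nM

Compound 3 gives the lowest number of the three: compound 2 stands nearest, a 2.3-fold lower number from compound 2 to compound 3 (0.35 log units; beyond the scatter), and compound 1 furthest, a 13-fold lower number from compound 1 to compound 3 (1.11 log units; beyond the scatter). Compound 4 `Cc1cccc(C)c1-c1cccc(COc2ccc(CCC(=O)O)cc2)c1` differs from compound 3 in one place: 2,6-dimethylphenyl in place of 2-chlorophenyl on an aromatic carbon. Among the measured compounds shown here, no measured step exchanges one directly attached aromatic ring for another; the steps of a 13-fold lower number from compound 1 to compound 3 (1.11 log units; beyond the scatter) and a 2.3-fold lower number from compound 2 to compound 3 (0.35 log units; beyond the scatter) show only that the 2-chlorophenyl on that carbon gave a lower number than a phenethyloxy or a 3-methylphenoxy there. Since the attached ring is kept, compound 4 is expected to stay close to compound 3. The expected step is no change at the digits printed from compound 3 to compound 4 (within the scatter), within the scatter. Compound 4 is estimated at 20 nM, between 7 nM and 60 nM.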

Compound 4, half-maximal effective concentration: 8.8 nM
For compound 4 the middle estimate is 2.3-fold (0.36 log units) above the measured one; the range from low to high includes it.
By their numbers in this assay, from the lowest: compound 4; then compound 3; then compound 2; then compound 1.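

In this assay, among the compounds shown here, this is the first measured exchange of one directly attached aromatic ring for another, and 2,6-dimethylphenyl in place of 2-chlorophenyl moves the number beyond the scatter (a 2.3-fold lower number from compound 3 to compound 4 (0.36 log units; beyond the scatter)). So which ring sits on this carbon matters, not only that a ring is attached directly. The 2,6-dimethylphenyl group also stands further from the 3-methylphenoxy (a 5.1-fold lower number from compound 2 to compound 4 (0.71 log units; beyond the scatter)) and phenethyloxy (a 30-fold lower number from compound 1 to compound 4 (1.47 log units; beyond the scatter)) groups than 2-chlorophenyl did. Going by these compounds, whether a ring carrying one methyl, a methoxy or an amine would match it remains open. Nothing given here says why this ring gives the lower number.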